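The compounds below may be only part of what the source reports. "The series", "measured", "known", "first", "only" and "open" are said of these compounds alone.

Compound 1 `NS(=O)(=O)c1ccc2nc(-n3nc(C(F)(F)F)cc3-c3ccco3)sc2c1` is examined in a functional assay on the whole organism (strain Wistar albino) for inhibition, with Rattus norvegicus as the target, read by paw edema, with stated times of 30 min and 3 h, at a dose of 50 mg/kg by the oral route (a lower number here means less inhibition, a higher number more inhibition at the dose given (going by the name of the read-out)), where compound 1 gives 61%. Among the three measured compounds it stands second highest. The nearest number belongs to compound 2 `NS(=O)(=O)c1ccc2nc(-n3nc(C(F)(F)F)cc3-c3ccc(F)cc3)sc2c1`, which in this assay gives 64%, and the furthest to compound 3 `NS(=O)(=O)c1ccc2nc(-n3nc(C(F)(F)F)cc3-c3ccccc3)sc2c1`, which in this assay gives 54%. Both steps away from compound 1 are small: a number 3 percentage points higher from compound 1 to compound 2 (within the scatter), and a number 7 percentage points lower from compound 1 to compound 3 (within the scatter). Likewise a number 10 percentage points lower from compound 2 to compound 3 (within the scatter) stays within the scatter, so the three measured compounds do not separate from one another.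

Compound 4 `NS(=O)(=O)c1ccc2nc(-n3nc(C(F)(F)F)cc3-c3cccs3)sc2c1` is not yet measured. It differs from compound 1 in one place: thiophen-2-yl in place of furan-2-yl on an aromatic carbon. For the measured compounds named here, the steps that bear on this change are the two in which the furan-2-yl of compound 1 gives way to another aromatic group, and neither of them left the scatter. A step of similar size, none beyond the scatter, is therefore expected, namely a number 1 percentage points lower from compound 1 to compound 4 (within the scatter) in this assay. Compound 4 is estimated at 60%, with a range from 48% to 72%.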

Compound 4, a percentage reported as inhibition, in the whole organism at one dose (the size of the read-out at that dose, not a potency): 49%
Beside the measured number, compound 4's estimate is 11 percentage points above it, and the stated range covers the measured number.
By their numbers in this assay, from the lowest: compounds 4, 3, 1 and 2 (each within the scatter of the next, the first and the last beyond it).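

In this assay, exchanging one five-membered aromatic ring with 1 hetero atom for another, with sulfur taking the place of oxygen and the heavy-atom count unchanged, gives a step beyond the scatter: a number 12 percentage points lower from compound 1 to compound 4 (beyond the scatter). The position next to the ring nitrogen therefore responds to the identity of the ring it carries, as does a number 15 percentage points lower from compound 2 to compound 4 (beyond the scatter), whereas a number 5 percentage points lower from compound 3 to compound 4 (within the scatter) leaves thiophen-2-yl and phenyl unseparated. Nothing shown here accounts for the difference between the sulfur and oxygen rings.

On these data alone, all four compounds carry an aromatic ring at this position, so it remains open how a saturated ring such as morpholine, a short alkyl chain or an amine would fare there. Also open, as far as these compounds go, is whether a methyl or chloro group on the thiophen-2-yl ring would shift the inhibition.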